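Swapping a sulfonyl piperazine for a hydroxypiperidine ether

This account rests on a few compounds, and the source may have more. Where it says the series, first, only, none or still open, it means among the compounds named here.

Compound 1 `O=S(=O)(c1ccc([C@H]2CC[C@]3(CC2)OOC2(O3)C3CC4CC(C3)CC2C4)cc1)N1CCNCC1` carries the shared core with a (piperazin-1-yl)sulfonyl group on its aromatic ring. Among the measured compounds shown here, in an ADME assay on microsomes from liver (Homo sapiens) for metabolic stability, read by LC-MS, tested at 1 uM (a higher number here means faster removal of the compound, a lower number slower removal), compound 1 gives 16 mL.min-1.g-1, the only outright number among the three measured compounds. Compound 2 `N[C@H]1CC[C@H](Oc2ccc([C@H]3CC[C@]4(CC3)OOC3(O4)C4CC5CC(C4)CC3C5)cc2)CC1` returns a limit of the assay, < 7 mL.min-1.g-1. Compound 3 `NCCCOc1ccc([C@H]2CC[C@]3(CC2)OOC2(O3)C3CC4CC(C3)CC2C4)cc1` likewise returns a limit, < 7 mL.min-1.g-1. Both sit at the limit of < 7 mL.min-1.g-1 in this assay, at which 2 of the 3 values shown sit, so the exact size of their gap to compound 1 is not known, only that it is an at least 2.2-fold lower number from compound 1 to compound 2 (0.35 log units; beyond the scatter) and an at least 2.2-fold lower number from compound 1 to compound 3 (0.35 log units; beyond the scatter).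

Compound 4 `OC1(COc2ccc([C@H]3CC[C@]4(CC3)OOC3(O4)C4CC5CC(C4)CC3C5)cc2)CCNCC1` is built from compound 1 by the change ((4-hydroxypiperidin-4-yl)methoxy in place of (piperazin-1-yl)sulfonyl on an aromatic carbon). The two measured steps that bear on it both replace the same (piperazin-1-yl)sulfonyl group on the same aromatic carbon, and both moved the value down past the limit. The same direction is therefore expected here, with a step of about a 3.2-fold lower number from compound 1 to compound 4 (0.51 log units; beyond the scatter), and compound 4 is estimated to come out near 5 mL.min-1.g-1, within 2 mL.min-1.g-1 to 12 mL.min-1.g-1, quite possibly again as a limit rather than a number.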

Compound 4, intrinsic clearance in microsomes: 16 mL.min-1.g-1
Compound 4: the middle estimate sits 3.2-fold (0.51 log units) below what was measured, and the stated range ends below it.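

In this assay, the sulfonyl link on this aromatic carbon can give way to an oxygen-linked group without any drop in the number: (4-hydroxypiperidin-4-yl)methoxy in place of (piperazin-1-yl)sulfonyl gives no change at the digits printed from compound 1 to compound 4 (within the scatter). The group attached through that oxygen therefore matters, with 4-hydroxypiperidin-4-yl in place of 2-aminoethyl giving an at least 2.2-fold higher number from compound 3 to compound 4 (0.35 log units; beyond the scatter), and (4-hydroxypiperidin-4-yl)methyl in place of 4-aminocyclohexyl giving an at least 2.2-fold higher number from compound 2 to compound 4 (0.35 log units; beyond the scatter). Both of these steps start from a limit rather than a number, so their true size is unknown: the limit of < 7 mL.min-1.g-1 in this assay, at which 2 of the 4 values shown sit.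

The compounds shown leave open whether the higher number goes with the hydroxyl or with the piperidine ring. Piperidin-4-ylmethoxy, the same group without its hydroxyl, would separate the two.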